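A few compounds are considered here, and "the series" means these few. Any claim that something is new, unique, unknown or untested is made for them only; others in the source may bear on it.

Compound 1 `CNC(=O)N1CCCc2ccc(NC(=O)c3ccc(-c4cnn(C)c4)cc3)cc21` gives 94.4% in a functional assay on MV4-11 cells (Homo sapiens) for antiproliferative activity, with a stated time of 6 days, tested at 6.25 uM; on this read-out higher numbers stand for a stronger effect at the one concentration tested and lower numbers for a weaker effect. Compound 2 `CNC(=O)N1CCCc2ccc(NC(=O)c3ccc(-c4ccccn4)cc3)cc21` gives 79.2% in this assay, and the step of a number 15.2 percentage points lower from compound 1 to compound 2 (beyond the scatter) is the only one measured so far; on these two numbers compound 2 stands lowest, with compound 1 the nearest and higher by a margin beyond the scatter. Compound 3 `CNC(=O)N1CCCc2ccc(NC(=O)c3ccc(-c4cn[nH]c4)cc3)cc21` is not yet measured. Its change from compound 2 is 1H-pyrazol-4-yl in place of pyridin-2-yl on an aromatic carbon. The step from compound 1 to compound 2 bears on this, since it swapped a pyrazolyl group for the pyridin-2-yl that now leaves; the present change returns a pyrazolyl ring, differing only in its 1H substitution. A rise of similar size, beyond the scatter, is therefore expected for compound 3, given the loss seen in a number 15.2 percentage points lower from compound 1 to compound 2 (beyond the scatter). The step from compound 2 to compound 3 is estimated at a number 10.8 percentage points higher from compound 2 to compound 3 (beyond the scatter). Compound 3 is estimated to give 90% in this assay, within 78% to 98%.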

Compound 3, a percentage reported as inhibition, at one concentration (the size of the read-out at that concentration, not a potency): 98.3%
For compound 3 the middle estimate is 8.3 percentage points below the measured one; measured number above the stated range.
By their numbers in this assay, from the lowest: compound 2; then compounds 1 and 3 (each within the scatter of the next).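

In this assay, 1H-pyrazol-4-yl in place of pyridin-2-yl gives a number 19.1 percentage points higher from compound 2 to compound 3 (beyond the scatter), so at this position, para to a large group, the lower number belongs to pyridin-2-yl and not to the loss of the methyl-bearing ring alone. The methyl on the pyrazole nitrogen is shown to be dispensable here: hydrogen in its place gives a number 3.9 percentage points higher from compound 1 to compound 3 (within the scatter), so the two pyrazoles cannot be told apart on this read-out. Nothing available explains the gap between the pyrazoles and pyridin-2-yl.

On these data alone, each number is the size of the effect at a single concentration, so whether the two pyrazoles would differ at other concentrations remains open. Also open, as far as these compounds go, is how far the pyrazole nitrogen tolerates substitution, for example a longer chain such as isopropyl or a chain ending in an amine, and whether pyridin-4-yl behaves like pyridin-2-yl.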